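The source may report more compounds than this note shows. Statements on the series, on what has been measured and on what is new or still open speak of the compounds shown alone.

Compound 3, whose structure is `COc1cc(C(=O)N2CC(C)OCC2C2CC(O)C2)cc2nc(N[C@H](C)c3cccc(Cl)c3)oc12`, gives 2 nM in an assay on isolated protein for inhibition of thyroid hormone receptor beta (Homo sapiens), read by fluorescence, with a stated time of 30 min; on this read-out lower numbers stand for stronger inhibition and higher numbers for weaker inhibition. Among the three compounds with numbers, compound 3 shows the lowest. Compound 2, drawn as `COc1cc(C(=O)N2CC(C)OCC2CO)cc2nc(N[C@H](C)c3cccc(Cl)c3)oc12`, gives 10 nM, and the change between them is a 5.0-fold lower number from compound 2 to compound 3 (0.70 log units; beyond the scatter). Compound 1, with the structure `COc1cc(C(=O)N2CCC(O)C(C)C2)cc2nc(NCc3cc(Cl)ccc3O)oc12`, gives 170 nM, far above the other two.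

Compound 4, drawn as `COc1cc(C(=O)N2CC(C)OCC2C2CC(O)C2)cc2nc(NCc3cc(Cl)ccn3)oc12`, has not yet been measured. Its structure differs from compound 3 in one place: (4-chloropyridin-2-yl)methyl in place of 1-(3-chlorophenyl)ethyl on a nitrogen on an aromatic ring. Among the measured compounds shown here, no measured pair tests this exact exchange. For the measured compounds named here, the only step that has been measured, from compound 2 to compound 3, concerns a different part of the molecule, the group on a saturated ring carbon, and gives no direct guide. Compound 1 carries a different arylmethyl group on the same nitrogen and lacks the stereocentre, but it also differs elsewhere, so its higher number cannot be attributed to the aromatic group alone.

The loss of the defined stereocentre together with the change of aromatic ring is expected to cost some potency, so compound 4 is estimated at 15 nM, between 4 nM and 60 nM, a step of a 7.5-fold higher number from compound 3 to compound 4 (0.88 log units; beyond the scatter).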

Compound 4, half-maximal inhibitory concentration: 8 nM
The estimate for compound 4 lay 1.9-fold (0.27 log units) above the measured number; the range from low to high includes it.
By their numbers in this assay, from the lowest: compound 3; then compounds 4 and 2 (each within the scatter of the next); then compound 1.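

This position, the group on a nitrogen on an aromatic ring, had never been read with the rest of the molecule held constant, and in this assay the exchange gives a 4.0-fold higher number from compound 3 to compound 4 (0.60 log units; beyond the scatter) as its first clean measure. That single change removes the defined stereocentre, takes one heavy atom away and brings in a ring nitrogen with a hydrogen-bond acceptor, yet compound 4 still reads 8 nM and so stays in the low range of the series, showing that this position accepts a chloropyridinyl ring in place of a chlorophenyl ring at a modest cost. No supporting measurement bears on why the number rises.

The compounds shown leave open how much of the step belongs to the lost stereocentre and how much to the ring change, which a (3-chlorophenyl)methyl or a 1-(4-chloropyridin-2-yl)ethyl group on the same nitrogen would separate. Also open, as far as these compounds go, is how this position responds to a ring carrying an amine or a carboxylic acid in place of the chlorine.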